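Two arrangements of one side group on a shared core

The compounds below may be only part of what the source reports. "The series", "measured", "known", "first", "only" and "open" are said of these compounds alone.

In a functional assay (aorta) with Rattus norvegicus as the target, in the presence of a further agent that is not named here (on this read-out lower numbers stand for an effect already at smaller amounts and higher numbers for an effect only at larger amounts of compound), compound 1 `COC(=O)C1=C(C)N=C(C)/C(=C(/O)OC)C1c1cccc(OCc2nonc2C)c1` gives 640 nM and compound 2 `COC(=O)C1=C(C)N=C(C)/C(=C(/O)OC)C1c1cccc(OCc2c(C(N)=O)no[n+]2[O-])c1` gives 1200 nM on the same read-out, so compound 2 lies within the scatter of compound 1. The change to compound 3 `COC(=O)C1=C(C)N=C(C)/C(=C(/O)OC)C1c1cccc(OCc2no[n+]([O-])c2C(N)=O)c1` is a group of 9 heavy atoms (3 carbon, 3 nitrogen, 3 oxygen; one five-membered aromatic ring with 3 hetero atoms) in place of a group of 9 heavy atoms (3 carbon, 3 nitrogen, 3 oxygen; one five-membered aromatic ring with 3 hetero atoms), on a saturated chain carbon bound to an oxygen on an aromatic ring and keeps the same atoms, joined differently. Within the data shown here, no measured step tests such a rearrangement. Among the measured compounds shown here, the one step that bears on it is a 1.9-fold higher number from compound 1 to compound 2 (0.27 log units; within the scatter) at that same place, an exchange that stayed within the scatter. As far as these compounds go, no step beyond the scatter is therefore expected in this assay for compound 3, and the direction stays open. The expected step is a 1.2-fold lower number from compound 2 to compound 3 (0.08 log units; within the scatter) in this estimate. For compound 3 the expected value is 1000 nM (range 400 nM to 2500 nM).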

Compound 3, half-maximal effective concentration: 710 nM
Compound 3: middle estimate off by 1.4-fold (0.15 log units), on the high side; the measured number falls inside the stated range.
By their numbers in this assay, from the lowest: compounds 1, 3 and 2 (each within the scatter of the next).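

Joining the same atoms differently, on a saturated chain carbon bound to an oxygen on an aromatic ring, gives a 1.7-fold lower number from compound 2 to compound 3 (0.23 log units; within the scatter) in this assay, the first direct test of such a rearrangement in the series. Set against the group of 6 heavy atoms, the new arrangement gives a 1.1-fold higher number from compound 1 to compound 3 (0.05 log units; within the scatter), so neither group of 9 heavy atoms separates from that smaller group on this read-out. Nothing available here bears on what lies behind these numbers.

As far as these compounds go, all three compounds carry a five-membered aromatic ring with 3 hetero atoms at this place, so it remains open whether a simple amine or a carboxylic acid there would give a step beyond the scatter. From the compounds shown here alone, it is also open whether the same rearrangement would stay within the scatter on a different core.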